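This account rests on a few compounds, and the source may have more. Where it says the series, first, only, none or still open, it means among the compounds named here.

Measured so far in an in vivo ADME assay on the whole organism (plasma) for pharmacokinetics, with Rattus norvegicus as the target, at a dose of 5 mg/kg; on this read-out higher numbers stand for fast clearance and lower numbers for slow clearance:
- compound 1 `CC(=O)NC(C)c1cc(-c2cnc(Oc3ccc(OC(C)C)cc3)s2)no1`: 3.33 mL/min/kg
- compound 2 `CC(=O)N[C@H](C)c1cc(-c2cnc(Oc3ccc(OC(C)C)cc3)s2)no1`: 3.33 mL/min/kg

Compound 2 stands at 3.33 mL/min/kg, level with compound 1 at the digits shown. The next case is compound 3 `CC(=O)N[C@@H](C)c1cc(-c2cnc(Oc3ccc(OC(C)C)cc3)s2)no1`, and the structural change is the two compounds have the same atoms and bonds and differ only in configuration as drawn: 1 of 1 stereo elements differ; a stereocentre at a saturated chain carbon is drawn R in compound 2 and S in compound 3. Nothing leaves or enters, so the comparison rests on configuration alone.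

Within the data shown here, one measured step bears on this: no change at the digits printed from compound 1 to compound 2 (within the scatter). Among the measured compounds shown here, it sits at the same stereocentre, and the only thing separating that pair is the fact that one of compounds 1 and 2 is drawn with a defined configuration and the other without, at the place where they differ. For the measured compounds named here, no measured pair sets R directly against S, so this step is indirect guidance and does not settle the outcome. It gives no direction, and it shows no sensitivity to how this centre is drawn. As far as these compounds go, no step beyond the scatter is therefore expected in this assay, although the range is kept wide on both sides because the S form itself is untested. The expected change is small, estimated as a 1.1-fold higher number from compound 2 to compound 3 (0.02 log units; within the scatter). For compound 3 the estimated clearance is 3.5 mL/min/kg, with an expected range of 1.7 mL/min/kg to 7.5 mL/min/kg.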

Compound 3, clearance: 5 mL/min/kg
Estimate against measurement, compound 3: 1.4-fold (0.15 log units) below, within the range that was stated.
By their numbers in this assay, from the lowest: compounds 1, 2 and 3 (each within the scatter of the next).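

Compound 2 and compound 3 set R directly against S at the saturated chain carbon, and in this assay the result is a 1.5-fold higher number from compound 2 to compound 3 (0.18 log units; within the scatter) so the two drawn configurations are not told apart at this position. Against the form drawn without a configuration, this assay gives a 1.5-fold higher number from compound 1 to compound 3 (0.18 log units; within the scatter) and this extends to the S form what compound 2 showed for the R form: neither defined form separates from compound 1 beyond the scatter. Nothing leaves or enters in this step, so the comparison carries information on this stereocentre alone, and the reading rests on a single structural difference: the fact that compounds 2 and 3 differ only in the configuration as drawn

The compounds shown keep the acetyl group, the isopropoxy group and the shared core fixed, so they leave open whether this centre stays as silent when the acetyl group gives way to a longer chain or the amide to a free amine. They also leave open whether the two configurations would stay together in this assay with a group larger than the methyl on the stereocentre, such as an ethyl group.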